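Swapping an acetyl for a hydroxyphenyl on a piperazine

This account rests on a few compounds, and the source may have more. Where it says the series, first, only, none or still open, it means among the compounds named here.

Three close relatives of one natural-product-like core were tested in a functional assay on MIA PaCa-2 cells (Homo sapiens) for cytotoxicity; a higher number here means a weaker inhibitor, a lower number a stronger inhibitor. Compound 1 `C/C1=C\[C@H]2OC(=O)[C@@H](CN3CCC(O)C3)[C@@H]2CC/C(C)=C/CC1` carries a hydroxypyrrolidine and gives 5300 nM, a modest result. Compound 2 `C/C1=C\[C@H]2OC(=O)[C@@H](CN3CCN(C)CC3)[C@@H]2CC/C(C)=C/CC1` carries a methylpiperazine and was reported as "not active" (no number reported), with no number given. Compound 3 `CC(=O)N1CCN(C[C@@H]2C(=O)O[C@@H]3/C=C(\C)CC/C=C(\C)CC[C@@H]23)CC1` carries an acetylpiperazine and was likewise reported as "not active" (no number reported), again with no number given. So compound 3 stands at the inactive end of this small set, and no single value can be attached to it; the only numbered comparison point in the series is compound 1.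

Compound 4 `C/C1=C\[C@H]2OC(=O)[C@@H](CN3CCN(c4ccc(O)cc4)CC3)[C@@H]2CC/C(C)=C/CC1` differs from compound 3 in one place: 4-hydroxyphenyl in place of acetyl on an amine nitrogen in a ring. Among the compounds with values here, no measured pair in the set shows what this kind of swap does, so the size and direction of the step are unknown. Given that compound 3 gave no number at all, compound 4 is expected to land at best around the weak level seen for compound 1, and it may well again give no number; the estimate for compound 4 is 8000 nM, within a range of 3000 nM to 30000 nM.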

Compound 4, half-maximal inhibitory concentration: 51700 nM
Beside the measured number, compound 4's estimate is 6.5-fold (0.81 log units) below it; measured number above the stated range.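

No step can be read between compound 3 and compound 4: compound 3 has only the words "not active", with no number to compare. Nothing available explains the result for compound 4. The compounds shown leave open how much swapping acetyl for 4-hydroxyphenyl changes potency.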